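Sulfonyl-linked indole hydroxamates: fluoro for methyl at the benzoyl

The compounds below may be only part of what the source reports. "The series", "measured", "known", "first", "only" and "open" are said of these compounds alone.

Measured compounds and their values:
compound 1 `O=C(NO)c1ccc(Cn2ccc3cc(C(=O)c4ccc(F)cc4)ccc32)cc1`, 9.25 nM
compound 2 `Cc1ccc(C(=O)c2ccc3c(ccn3S(=O)(=O)c3cccc(/C=C/C(=O)NO)c3)c2)cc1`, 2750 nM
compound 3 `COc1cc(C(=O)c2ccc3c(ccn3Cc3ccc(C(=O)NO)cc3)c2)cc(OC)c1OC`, 1540 nM

In an assay on isolated protein for inhibition of protein deacetylase HDAC6 (Homo sapiens) (on this read-out lower numbers stand for stronger inhibition and higher numbers for weaker inhibition), compound 2 sits at the high end of the numbers seen so far: compound 1 lies far away on the stronger side, beyond the scatter, whereas compound 3 lies within the scatter of compound 2, so no order between those two can be read. Compound 4 `O=C(/C=C/c1cccc(S(=O)(=O)n2ccc3cc(C(=O)c4ccc(F)cc4)ccc32)c1)NO` keeps the sulfonyl linker and the cinnamic hydroxamate of compound 2 and differs only in fluoro in place of methyl on an aromatic carbon. For the measured compounds named here, no measured pair shows this exchange, so the expected step from compound 2 to compound 4 in this assay is small, if anything toward a slightly lower number, and likely within the scatter, about a 1.4-fold lower number from compound 2 to compound 4 (0.14 log units; within the scatter). Compound 4 is thus expected near 2000 nM, in the range 700 nM to 6000 nM.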

Compound 4, half-maximal inhibitory concentration: 1420 nM
The estimate for compound 4 lay 1.4-fold (0.15 log units) above the measured number; low and high end bracket the measured number.
By their numbers in this assay, from the lowest: compound 1; then compounds 4, 3 and 2 (each within the scatter of the next).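

In this assay, for the compounds shown here, 4-fluorophenyl in place of 4-methylphenyl at the carbonyl gives a 1.9-fold lower number from compound 2 to compound 4 (0.29 log units; within the scatter), the first reading of this exchange, made with the sulfonyl linker and cinnamic hydroxamate held fixed. With that linker, this position therefore takes either fluoro or methyl without a readable change in the number. Nothing on hand accounts for the step.

From the compounds shown here alone, whether an amine, a carboxylic acid or a longer chain at this position would move the number beyond the scatter stays open. So does whether the same exchange would read alike with the linker and hydroxamate of compound 1.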